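Trimethoxyphenyl triazole thioethers: para substituent on phenyl ketone

A few compounds are considered here, and "the series" means these few. Any claim that something is new, unique, unknown or untested is made for them only; others in the source may bear on it.

Measured compounds in a functional assay on PC-3 cells (Homo sapiens) for antiproliferative activity, read by MTT assay, with a stated time of 48 h; on this read-out lower numbers stand for stronger inhibition and higher numbers for weaker inhibition:
- compound 1 `COc1cc(-c2nnc(SCC(=O)c3ccccc3)n2N)cc(OC)c1OC`: > 100000 nM
- compound 2 `COc1cc(-c2nnc(SCC(=O)c3ccc(Cl)cc3)n2N)cc(OC)c1OC`: > 100000 nM
- compound 3 `COc1cc(-c2nnc(SCC(=O)c3ccc(C)cc3)n2N)cc(OC)c1OC`: 31300 nM

Compound 1 gives a value that is a limit of the assay. Compound 2 also sits at a limit of the assay, not a number; it shares the shared core with the others and carries a chloro on the aromatic carbon. The step that the two limits leave unreadable from compound 1 to compound 2 is therefore unreadable. The steps of an at least 3.1-fold lower number from compound 1 to compound 3 (0.50 log units; beyond the scatter) and an at least 3.1-fold lower number from compound 2 to compound 3 (0.50 log units; beyond the scatter) show that methyl gives a readable number, with reference to the limit of > 100000 nM in this assay, at which 2 of the 3 values shown sit.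

Compound 4 `COc1cc(-c2nnc(SCC(=O)c3ccc(F)cc3)n2N)cc(OC)c1OC` differs from compound 2 by fluoro in place of chloro on an aromatic carbon. Among the measured compounds shown here, no measured step covers fluoro in place of chloro. Compound 4 is expected to give 100000 nM (range 30000 nM to 300000 nM). The expected step is a number no higher from compound 2 to compound 4 (the limit leaves the size open), none beyond the scatter.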

Compound 4, half-maximal inhibitory concentration: > 100000 nM
Compound 4: no number, only a limit; the forecaster's own chance of this, stated with the estimate: 65%; the middle value lies on the limit itself.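

Compound 4 also sits at a limit of the assay and gives no number, so its steps against compound 1 and compound 2 cannot be read. Among the groups shown on this aromatic carbon, in this assay only methyl gives a number. Fluoro in place of methyl brings an at least 3.1-fold higher number from compound 3 to compound 4 (0.50 log units; beyond the scatter) and places fluoro with hydrogen and chloro at the limit, which now holds most of the series: the limit of > 100000 nM in this assay, at which 3 of the 4 values shown sit.

On these data alone, how far compounds 1, 2 and 4 lie from one another stays open. Also open, as far as these compounds go, is whether an ethyl, a methoxy or an amine on this carbon would give a number.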